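A few compounds are considered here, and "the series" means these few. Any claim that something is new, unique, unknown or untested is made for them only; others in the source may bear on it.

Among the compounds with values here, in a functional assay on HeLa cells (Homo sapiens) for cytotoxicity, read by MTT assay, with a stated time of 48 h (a higher number here means a weaker inhibitor, a lower number a stronger inhibitor), the compounds measured so far have yielded no number. Compound 1 `O=c1ccoc2cc(OCc3cn(Cc4ccccc4)nn3)ccc12` gives > 100000 nM, which is a limit. Compound 2 `Cc1cccc(Cn2cc(COc3ccc4c(=O)ccoc4c3)nn2)c1` gives > 100000 nM, which is also a limit. Compound 3 `O=c1ccoc2cc(OCc3cn(Cc4cccc(Br)c4)nn3)ccc12` gives > 100000 nM, again a limit. Compound 3 therefore has no exact position, and the record shows only (the limit of > 100000 nM in this assay, at which 3 of the 3 values shown sit).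

Compound 4 `O=c1ccoc2cc(OCc3cn(Cc4ccc(F)cc4)nn3)ccc12` differs from compound 3 by one change: 4-fluorophenyl in place of 3-bromophenyl on a saturated chain carbon bound to an aromatic nitrogen, with 4-fluorophenyl in place of 3-bromophenyl on a saturated chain carbon bound to an aromatic nitrogen. Within the data shown here, three measured steps bear on this change. Among the measured compounds shown here, the first is a step that the two limits leave unreadable from compound 1 to compound 2, the second is a step that the two limits leave unreadable from compound 1 to compound 3, and the third is a step that the two limits leave unreadable from compound 2 to compound 3. None of them offers a size or a direction to carry over, so no step beyond the scatter is expected in this assay. The expected change is a number no higher from compound 3 to compound 4 (the limit leaves the size open). The estimated value for compound 4 is 100000 nM, within an expected range from 40000 nM to 200000 nM.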

Compound 4, half-maximal inhibitory concentration: 12000 nM
Compound 4: the middle estimate sits 8.3-fold (0.92 log units) above what was measured; measured number outside the range, below it.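

In this assay, the place on a saturated chain carbon bound to an aromatic nitrogen now proves able to move the read-out, as 4-fluorophenyl gives the first exact number, whereas the other compounds shown stop at a limit: the limit of > 100000 nM in this assay, at which 3 of the 4 values shown sit.

A fluoro group where there was none gives an at least 8.3-fold lower number from compound 1 to compound 4 (0.92 log units; beyond the scatter), 4-fluorophenyl in place of 3-methylphenyl gives an at least 8.3-fold lower number from compound 2 to compound 4 (0.92 log units; beyond the scatter), and 4-fluorophenyl in place of 3-bromophenyl gives an at least 8.3-fold lower number from compound 3 to compound 4 (0.92 log units; beyond the scatter). On these data alone, each of these steps starts from a limit, so its true size stays open.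

The compounds shown leave open whether the exact number follows the fluoro group itself or its placing in 4-fluorophenyl, which a 3-fluorophenyl or 4-bromophenyl group could separate. As far as these compounds go, how an amine or a carboxylic acid on that aromatic ring would read also remains unknown.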